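Methoxy for Fluoro on the Amide Aryl Group

This account rests on a few compounds, and the source may have more. Where it says the series, first, only, none or still open, it means among the compounds named here.

The series rests on a shared core carrying an amide. Compound 1 `O=C(Nc1c(C(O)(C(F)(F)F)C(F)(F)F)ccc2ccccc12)C1CCC1` bears a cyclobutyl group on the carbonyl carbon, and in an assay on LtK cells with ATP-sensitive inward rectifier potassium channel 11 (Homo sapiens) as the target (on this read-out higher numbers stand for an effect only at larger amounts of compound and lower numbers for an effect already at smaller amounts), compound 1 gives 45 nM. Compound 2 `O=C(Nc1c(C(O)(C(F)(F)F)C(F)(F)F)ccc2ccccc12)c1ccc(F)cc1` carries a 4-fluorophenyl group in that position, and in this assay compound 2 gives 70 nM. The change between them reads a 1.6-fold higher number from compound 1 to compound 2 (0.19 log units; within the scatter). Compound 2 thus holds the higher of the two numbers recorded so far, with compound 1 as its nearest neighbour at a distance that stays within the scatter.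

Compound 3 `COc1ccc(C(=O)Nc2c(C(O)(C(F)(F)F)C(F)(F)F)ccc3ccccc23)cc1` differs from compound 2 by methoxy in place of fluoro on an aromatic carbon. Among the compounds with values here, no measured step touches the substituent on that aromatic ring; the only step available, which concerns the group on the carbonyl carbon, was itself within the scatter. On this basis no step beyond the scatter is expected in this assay for compound 3, which is estimated at 80 nM, within a range of 35 nM to 180 nM. That estimate amounts to a step of a 1.1-fold higher number from compound 2 to compound 3 (0.06 log units; within the scatter).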

Compound 3, half-maximal effective concentration: 417 nM
The estimate for compound 3 lay 5.2-fold (0.72 log units) below the measured number, outside the stated range (above it).
By their numbers in this assay, from the lowest: compounds 1 and 2 (each within the scatter of the next); then compound 3.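

Methoxy in place of fluoro, on an aromatic carbon para to a large group, is the first change here to move the number in this assay beyond the scatter, with a 6.0-fold higher number from compound 2 to compound 3 (0.78 log units; beyond the scatter) as its step. This shows that the substituent at this ring position matters on this read-out, even though the earlier exchange of cyclobutyl for 4-fluorophenyl on the carbonyl carbon stayed within the scatter, and the comparison with the cyclobutyl amide now reads a 9.3-fold higher number from compound 1 to compound 3 (0.97 log units; beyond the scatter) as a step beyond the scatter for 4-methoxyphenyl in place of cyclobutyl. No measurement available here bears on what lies behind this step, which therefore stands as an observation from a single pair of compounds.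

The compounds shown leave open whether other groups at this position, such as chloro, hydroxy, ethoxy or an amine, would fall nearer to fluoro or to methoxy in their numbers. They also leave open whether a longer alkoxy chain would carry the step further, or whether hydrogen at that position would give a number close to that of fluoro.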